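Replacing the Biphenyl Phenyl with Chloro in a Dibromo Amide

The source may hold more compounds than are shown below. What is called first, only, known or untested is meant among the compounds shown, and "the series" means these compounds.

Measured in a functional assay on A2780 cells (Homo sapiens) for inhibition, read by MTT assay, with a stated time of 72 h; a lower number here means a stronger inhibitor of growth, a higher number a weaker inhibitor of growth:
Compound 1 `O=C(NCc1ccc(-c2ccccc2)cc1)c1ccc[nH]1`: 11000 nM
Compound 2 `O=C(NCc1ccc(-c2ccccc2)cc1)c1cc(Br)c(Br)[nH]1`: 6400 nM
Compound 3 `O=C(NCc1ccc(Cl)c(Cl)c1)c1cc(Br)c(Br)[nH]1`: 15000 nM

In this assay compound 2 gives 6400 nM. That number lies within the scatter of the value for compound 1, while compound 3 has a higher number, with a gap beyond the scatter.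

The next compound is compound 4 `O=C(NCc1ccc(Cl)cc1)c1cc(Br)c(Br)[nH]1`, which differs from compound 2 by chloro in place of phenyl on an aromatic carbon, para to a large group.

For the measured compounds named here, no measured step makes this exchange. Going by the values given here, the one measured step, a 1.7-fold lower number from compound 1 to compound 2 (0.24 log units; within the scatter), concerns a different place, the 4,5-dibromo-1H-pyrrol-2-yl group, and offers no direct guide. The closest evidence is compound 3 at 15000 nM, which keeps that group and has chloro substitution with no phenyl. This single comparison suggests a modest rise in the number, though compound 3 is not a matched pair for this change. The expected shift is a 2.2-fold higher number from compound 2 to compound 4 (0.34 log units; beyond the scatter), towards weaker growth inhibition. For compound 4 the estimated value is 14000 nM, with an expected range of 6000 nM to 32000 nM.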

Compound 4, concentration for 50% growth inhibition: 13000 nM
The estimate for compound 4 lay 1.1-fold (0.03 log units) above the measured number, within the range that was stated.
By their numbers in this assay, from the lowest: compounds 2, 1, 4 and 3 (each within the scatter of the next, the first and the last beyond it).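

With the 4,5-dibromo-1H-pyrrol-2-yl group held constant, the exchange of phenyl for chloro on this aromatic carbon can now be read directly in this assay (a 2.0-fold higher number from compound 2 to compound 4 (0.31 log units; beyond the scatter)), a modest step towards weaker growth inhibition that replaces a six-membered aromatic ring of carbon only with a single chlorine atom. The other new step concerns a different place on the same benzyl portion, where hydrogen stands in place of chloro (a 1.2-fold lower number from compound 3 to compound 4 (0.06 log units; within the scatter)), so this second chloro makes no difference that can be told from the scatter in this pair. Nothing at hand gives a reason for either step.

The compounds shown leave open how other groups at the place para to a large group would behave, such as methoxy, an amine or a carboxylic acid, and whether a second aromatic ring carrying its own substituents would differ from the plain phenyl of compound 2. From the compounds shown here alone, it also remains open whether the exchange of phenyl for chloro would give a step of similar size with the unsubstituted 1H-pyrrol-2-yl group of compound 1.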